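Removing the alpha aryl group: compound 2 to compound 3

The source may hold more compounds than are shown below. What is called first, only, known or untested is meant among the compounds shown, and "the series" means these compounds.

Measured so far:
compound 1, `CCCCCCCCCCCCn1nnc(C(C(=O)Nc2ncccc2C)c2ccccc2)n1`, in an assay on liver for inhibition of sterol O-acyltransferase 1 (Rattus norvegicus), using microsomes (on this read-out higher numbers stand for weaker inhibition and lower numbers for stronger inhibition), compound 1 gives 85 nM
compound 2, `CCCCCCCCCCCCn1nnc(C(C(=O)Nc2c(OC)cc(OC)cc2OC)c2ccc(OC)cc2)n1`, in this assay compound 2 gives 200 nM

Compound 2 has the higher of the two numbers in this assay; compound 1 sits at a lower number, and the gap between the two lies beyond the scatter. Compound 3, `CCCCCCCCCCCCn1nnc(CC(=O)Nc2c(OC)cc(OC)cc2OC)n1`, differs from compound 2 only by hydrogen in place of 4-methoxyphenyl on a saturated chain carbon bound to an aromatic carbon and a carbonyl carbon. Going by the values given here, no measured pair shows this change, so the expectation rests on the change itself. The step is expected to weaken inhibition in this assay beyond the scatter, by about a 5.0-fold higher number from compound 2 to compound 3 (0.70 log units; beyond the scatter). For compound 3 the estimate in this assay is 1000 nM, with a range from 300 nM to 4000 nM.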

Compound 3, half-maximal inhibitory concentration: 24 nM
Compound 3: middle estimate off by 42-fold (1.62 log units), on the high side; the measured number lies below the stated range.
By their numbers in this assay, from the lowest: compound 3; then compound 1; then compound 2.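

Replacing 4-methoxyphenyl with hydrogen on this saturated chain carbon gives an 8.3-fold lower number from compound 2 to compound 3 (0.92 log units; beyond the scatter) in this assay and so strengthens inhibition. With the rest of compound 2 held fixed, the aryl group is therefore not needed at this position, and removing it is a clear gain. Nothing available explains why this position behaves this way.

From the compounds shown here alone, whether a methyl group or an amine on this carbon would keep the gain remains open. Also open, going by these compounds, is whether removing the phenyl group from compound 1 would have the same effect.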